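The compounds below may be only part of what the source reports. "The series", "measured", "known", "first", "only" and "open" are said of these compounds alone.

Among the measured compounds shown here, compound 1 `CCCCCCCCCCCC(=O)OC[C@H](CSC[C@@H](N)C(=O)N[C@@H](C)CO)OC(=O)CCCCCCCCCCC` was tested in an assay on HEK293 cells for agonist activity at Toll-like receptor 2 (Homo sapiens) (a higher number here means that more compound is needed for the effect, a lower number that less compound is needed), and in that test compound 1 gives 1560 nM, the lowest of the three numbers measured so far. Compound 2 `CCCCCCCCCCCC(=O)OC[C@H](CSC[C@@H](N)C(=O)N[C@H](C)CO)OC(=O)CCCCCCCCCCC` gives 22200 nM; the step of a 14-fold higher number from compound 1 to compound 2 (1.15 log units; beyond the scatter) rests on nothing more than the fact that compounds 1 and 2 differ only in the configuration as drawn. Compound 3 `CCCCCCCCCCCC(=O)OC[C@H](CSC[C@@H](N)C(=O)NCCCC(C)(C)CO)OC(=O)CCCCCCCCCCC` gives 30700 nM, and the step of a 20-fold higher number from compound 1 to compound 3 (1.29 log units; beyond the scatter) shows that exchanging the group on the amide-type nitrogen for a longer one also raised the number. Compound 4 `CCCCCCCCCCCC(=O)OC[C@H](CSC[C@@H](N)C(=O)NC(C)c1ccccc1)OC(=O)CCCCCCCCCCC` has not yet been measured. It differs from compound 1 in one place: 1-phenylethyl in place of 1-(hydroxymethyl)ethyl on an amide-type nitrogen. Both measured steps start from compound 1 and both went towards a higher number, beyond the usual scatter, and the change in compound 4 once more replaces the group on the amide-type nitrogen, so a step of similar size towards a higher number is expected. For compound 4 the expected step is a 9.6-fold higher number from compound 1 to compound 4 (0.98 log units; beyond the scatter). The estimate for compound 4 in this assay is 15000 nM, with a range from 3000 nM to 60000 nM.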

Compound 4, half-maximal effective concentration: 9900 nM
Compound 4: middle estimate off by 1.5-fold (0.18 log units), on the high side; the measured number falls inside the stated range.
By their numbers in this assay, from the lowest: compound 1; then compound 4; then compounds 2 and 3 (each within the scatter of the next).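

In this assay, 1-phenylethyl in place of 1-(hydroxymethyl)ethyl on the amide-type nitrogen gives a 6.3-fold higher number from compound 1 to compound 4 (0.80 log units; beyond the scatter), so a group with an aromatic ring and no hydrogen-bond donor or acceptor keeps some activity here without matching compound 1. Not every change at this position costs the same, as the other two steps show: a 2.2-fold lower number from compound 2 to compound 4 (0.35 log units; beyond the scatter) and a 3.1-fold lower number from compound 3 to compound 4 (0.49 log units; beyond the scatter). The entering group has no defined stereocentre, and configuration in the group at this position can matter a great deal, as the large step between two otherwise identical compounds shows: the fact that compounds 1 and 2 differ only in the configuration as drawn.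

The compounds shown remove the hydroxyl and add the ring together, leaving open which of the two sets the step, and the two configurations of 1-phenylethyl remain unseparated. From the compounds shown here alone, how an amine or a carboxylic acid in place of that hydroxyl would behave also remains open.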